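Replacing the 4,6-diaminopyrimidin-2-yl group of compound 2

The source may hold more compounds than are shown below. What is called first, only, known or untested is meant among the compounds shown, and "the series" means these compounds.

In a functional assay on aorta (Rattus norvegicus, strain Sprague-Dawley) (a higher number here means that more compound is needed for the effect, a lower number that less compound is needed), compound 1 `Cc1ccccc1COc1nc2c(cc1-c1nc(N)cc(N)n1)c(C)nn2-c1ccccc1` gives 290 nM and compound 2 `Cc1nn(-c2ccccc2)c2nc(OCc3ccccc3F)c(-c3nc(N)cc(N)n3)cc12` gives 2200 nM, so compound 2 has the higher of these two numbers. This gap, a 7.6-fold higher number from compound 1 to compound 2 (0.88 log units; beyond the scatter), comes with fluoro in place of methyl on an aromatic carbon. Compound 3 `CCCCOC(=O)Nc1c(N)nc(-c2cc3c(C)nn(-c4ccccc4)c3nc2OCc2ccccc2F)nc1N` is reported only as a limit of the assay, > 100000 nM.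

Compound 4 `Cc1nn(-c2ccccc2)c2nc(OCc3ccccc3F)c(-c3nc(N)c4c(n3)[nH]c(=O)n4C)cc12` departs from compound 2 in one place: a group of 12 heavy atoms (6 carbon, 5 nitrogen, 1 oxygen; one five-membered aromatic ring with 2 hetero atoms, one six-membered aromatic ring with 2 hetero atoms) in place of a group of 8 heavy atoms (4 carbon, 4 nitrogen; one six-membered aromatic ring with 2 hetero atoms), on an aromatic carbon. The change lies ortho to a (2-fluorobenzyl)oxy group. The most relevant measured step is an at least 45-fold higher number from compound 2 to compound 3 (1.65 log units; beyond the scatter), which also alters the 4,6-diaminopyrimidin-2-yl group. The fluoro for methyl step alters another part of the molecule and bears on this change less directly. A higher number is therefore expected in this assay, with a step larger than the fluoro for methyl step but smaller than the step to compound 3. The expected change is a 9.1-fold higher number from compound 2 to compound 4 (0.96 log units; beyond the scatter). For compound 4, the estimated value is 20000 nM, within an expected range of 4000 nM to 90000 nM.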

Compound 4, half-maximal effective concentration: 4900 nM
Compound 4: the middle estimate sits 4.1-fold (0.61 log units) above what was measured, within the range that was stated.
By their numbers in this assay, from the lowest: compound 1; then compound 2; then compound 4. At a limit, above all of these: compound 3.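

At this position the larger group of compound 4, with one five-membered and one six-membered aromatic ring, brings only a modest change in this assay: a 2.2-fold higher number from compound 2 to compound 4 (0.35 log units; beyond the scatter). Adding a second ring on this aromatic carbon therefore does not by itself drive the number up steeply, and compound 4 stays measurable. Compound 3, with its (butoxycarbonyl)amino group on the 4,6-diaminopyrimidin-2-yl ring, is reported only as a limit of the assay: the limit of > 100000 nM in this assay, at which 1 of the 4 values shown sits.

The compounds shown leave open which part of the new group accounts for the step, since its carbonyl and its methyl group are never varied alone. They also leave open whether a smaller acetylamino group or a carboxylic acid on the 4,6-diaminopyrimidin-2-yl ring would stay measurable in this assay.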